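The compounds below may be only part of what the source reports. "The series", "measured", "known", "first", "only" and "open" are said of these compounds alone.

In a functional assay on DU-145 cells (Homo sapiens) for inhibition, read by trypan blue exclusion, with a stated time of 72 h (a lower number here means a stronger inhibitor, a higher number a weaker inhibitor), three compounds with a shared core differ only in the group on a sulfonyl sulfur. Compound 1 `Cn1c(=O)c(S(=O)(=O)Cc2ccc(F)cc2)cc2cnc(Nc3ccc4[nH]ccc4c3)nc21`, with 4-fluorobenzyl, gives 30000 nM. Compound 2 `Cn1c(=O)c(S(=O)(=O)c2ccc(F)cc2)cc2cnc(Nc3ccc4[nH]ccc4c3)nc21`, with 4-fluorophenyl, gives 300 nM. Compound 3 `Cn1c(=O)c(S(=O)(=O)Nc2ccc(F)cc2)cc2cnc(Nc3ccc4[nH]ccc4c3)nc21`, with (4-fluorophenyl)amino, gives 5000 nM, the middle of these three numbers.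

Compound 4 `Cn1c(=O)c(S(=O)(=O)c2ccc(F)cc2[N+](=O)[O-])cc2cnc(Nc3ccc4[nH]ccc4c3)nc21` replaces (4-fluorophenyl)amino with 4-fluoro-2-nitrophenyl: 4-fluoro-2-nitrophenyl in place of (4-fluorophenyl)amino on a sulfonyl sulfur. Like compound 2, it has a phenyl group on the sulfur, so the most relevant measurement is the large change a 17-fold higher number from compound 2 to compound 3 (1.22 log units; beyond the scatter), which compound 4 could largely reverse. The large change a 100-fold lower number from compound 1 to compound 2 (2.00 log units; beyond the scatter) and the modest change a 6.0-fold lower number from compound 1 to compound 3 (0.78 log units; beyond the scatter) confirm that this group matters. Going by the values given here, no measured compound carries a nitro group, so uncertainty remains. A clear move to a stronger inhibitor is expected, an 8.3-fold lower number from compound 3 to compound 4 (0.92 log units; beyond the scatter). For compound 4, the estimated value is 600 nM, within a range of 150 nM to 3000 nM.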

Compound 4, half-maximal inhibitory concentration: 1500 nM
Beside the measured number, compound 4's estimate is 2.5-fold (0.40 log units) below it; low and high end bracket the measured number.
By their numbers in this assay, from the lowest: compound 2; then compound 4; then compound 3; then compound 1.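

In this assay, nitro in place of hydrogen on an aromatic carbon of the 4-fluorophenyl group gives a weaker inhibitor (a 5.0-fold higher number from compound 2 to compound 4 (0.70 log units; beyond the scatter)), so this ring is sensitive to an added group. Even so, 4-fluoro-2-nitrophenyl on the sulfonyl sulfur still gives a stronger inhibitor than (4-fluorophenyl)amino (a 3.3-fold lower number from compound 3 to compound 4 (0.52 log units; beyond the scatter)) or 4-fluorobenzyl (a 20-fold lower number from compound 1 to compound 4 (1.30 log units; beyond the scatter)). Nothing available explains these shifts.

Still open, from the compounds shown here alone, is whether the loss comes with nitro specifically. A methyl, an amine or a carboxylic acid on that ring could behave differently.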